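Hydroxy in place of trifluoromethyl on the secondary-amine core

A few compounds are considered here, and "the series" means these few. Any claim that something is new, unique, unknown or untested is made for them only; others in the source may bear on it.

For the measured compounds named here, in a functional assay on PC-3 cells (Homo sapiens) for inhibition, read by sulforhodamine B assay, with a stated time of 48 h (a lower number here means a stronger inhibitor of growth, a higher number a weaker inhibitor of growth), compound 2 `O=C(Nc1ccc(C(F)(F)F)cc1)C1NCCc2ccccc21` gives 6590 nM, the highest of the three numbers so far. Compound 1 `O=C(Nc1ccc(C(F)(F)F)cc1)C1c2ccccc2CCN1C(=O)c1ccc(Cl)cc1` gives 4490 nM; the step of a 1.5-fold higher number from compound 1 to compound 2 (0.17 log units; within the scatter) lies within the scatter. Compound 3 `COc1ccccc1NC(=O)C1c2ccccc2CCN1C(=O)c1ccc(Cl)cc1` gives 2010 nM, which lies beyond the scatter from compound 2. Compound 4 `O=C(Nc1ccc(O)cc1)C1NCCc2ccccc21` differs from compound 2 by hydroxy in place of trifluoromethyl on an aromatic carbon. Going by the values given here, no measured step changes this group on this core. The nearest comparison is the exchange of the aryl on the amide nitrogen, a 2.2-fold lower number from compound 1 to compound 3 (0.35 log units; beyond the scatter), a modest step, while a 1.5-fold higher number from compound 1 to compound 2 (0.17 log units; within the scatter) stays within the scatter. A modest lowering at most is therefore expected for compound 4 in this assay, estimated at 4000 nM with a range of 1300 nM to 12000 nM. The step this implies, a 1.6-fold lower number from compound 2 to compound 4 (0.22 log units; within the scatter), is expected to stay close to the scatter.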

Compound 4, concentration for 50% growth inhibition: 4250 nM
Estimate against measurement, compound 4: 1.1-fold (0.03 log units) below; low and high end bracket the measured number.
By their numbers in this assay, from the lowest: compound 3; then compounds 4, 1 and 2 (each within the scatter of the next).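

In this assay, the exchange at this aromatic carbon gives a 1.6-fold lower number from compound 2 to compound 4 (0.19 log units; within the scatter) for hydroxy in place of trifluoromethyl. On the core of compound 2, this position therefore takes either group without a step beyond the scatter, although hydroxy brings a hydrogen-bond donor and acceptor that trifluoromethyl lacks. No measurement available here gives a reason for this result.

On these data alone, whether an amine or a carboxylic acid at this carbon would also stay within the scatter remains open. So does the effect of hydroxy when the ring nitrogen carries the (4-chlorophenyl)carbonyl group of compound 1.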